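From a Methyl to a Methoxy Group at the Weak End

The source may report more compounds than this note shows. Statements on the series, on what has been measured and on what is new or still open speak of the compounds shown alone.

Measured compounds:
compound 1 `Cn1cc(/C=C2/C(=O)Nc3ccccc32)c2cc(Nc3nccc(-c4ccccc4)n3)ccc21`: 42900 nM
compound 2 `Cc1ccc(-c2ccnc(Nc3ccc4c(c3)c(/C=C3/C(=O)Nc5ccccc53)cn4C)n2)cc1`: > 100000 nM

In a functional assay on MCF7 cells (Homo sapiens) for cytotoxicity, read by MTT assay, with a stated time of 48 h (a lower number here means a stronger inhibitor, a higher number a weaker inhibitor), compound 1 gives 42900 nM. For compound 2 the assay reports only a limit, > 100000 nM. The step of an at least 2.3-fold higher number from compound 1 to compound 2 (0.36 log units; beyond the scatter) therefore shows that the added methyl made the inhibitor weaker, and compound 2 stands at the limit of > 100000 nM in this assay, at which 1 of the 2 values shown sits, the weakest point the numbers can show.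

Compound 3 `COc1ccc(-c2ccnc(Nc3ccc4c(c3)c(/C=C3/C(=O)Nc5ccccc53)cn4C)n2)cc1` differs from compound 2 by methoxy in place of methyl on an aromatic carbon. Going by the values given here, no measured step compares a methyl with a methoxy group, so the only guide is that compound 2 already sits at the limit. Compound 3 is expected to stay close to compound 2, with a number no higher from compound 2 to compound 3 (the limit leaves the size open), a step not expected to reach beyond the scatter. The estimate for compound 3 in this assay is 100000 nM, with a range from 40000 nM to 250000 nM.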

Compound 3, half-maximal inhibitory concentration: > 100000 nM
Compound 3: only a limit was reported; the forecaster's own chance of this, stated with the estimate: 55%; the middle value sits exactly at the limit.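

With 4-methoxyphenyl in place of the plain phenyl ring of compound 1, this assay gives an at least 2.3-fold higher number from compound 1 to compound 3 (0.36 log units; beyond the scatter). The added group sits on the same aromatic carbon, para to a large group, so the loss of strength seen with methyl also appears with a second, larger group that carries an oxygen. The step between compound 2 and compound 3 cannot be read, and methyl and methoxy cannot be ranked against each other, because both compounds sit at the same limit: the limit of > 100000 nM in this assay, at which 2 of the 3 values shown sit.

The compounds shown leave open how much weaker compound 2 and compound 3 really are, since a limit gives no exact number. They also leave open whether a smaller or very different group on this carbon, such as a fluorine atom, an amine or a carboxylic acid, would keep the strength of compound 1 or improve on it.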